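This account rests on a few compounds, and the source may have more. Where it says the series, first, only, none or still open, it means among the compounds named here.

Measured in a functional assay on HL-60 cells (Homo sapiens) for cytotoxicity, read by WST assay, with a stated time of 48 h; a higher number here means that more compound is needed for the effect, a lower number that less compound is needed:

- Compound 1 `O=C1OC[C@H](Cc2ccccc2)[C@H]1Cc1ccccc1Cl`: 37000 nM
- Compound 2 `Clc1ccc(C[C@H]2COC[C@@H]2Cc2ccccc2)cc1Cl`: 19000 nM
- Compound 3 `Cc1ccc(C[C@H]2COC(=O)[C@@H]2Cc2ccc(Cl)c(Cl)c2)cc1C`: 16000 nM

These three compounds make up the whole of the measured series. Compound 2, at 19000 nM, lies within the usual scatter of both other compounds, so its number cannot be told apart from either of theirs. The account now turns to compound 4 `Cc1cccc(C[C@H]2COC[C@@H]2Cc2ccc(Cl)c(Cl)c2)c1`, which has not yet been measured in this assay. It differs from compound 2 by a single change: methyl in place of hydrogen on an aromatic carbon. Put simply, a methyl stands in place of a hydrogen on an aromatic carbon.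

Going by the values given here, no measured pair isolates this change, so the data give no direct size for it. The nearest evidence is compound 3, which also carries methyl on aromatic carbons and gives 16000 nM. That value sits within the scatter of compound 2, so only a small step is expected, with at most a slight lean toward a lower number and nothing beyond the scatter. The expected change is a 1.3-fold lower number from compound 2 to compound 4 (0.10 log units; within the scatter). For compound 4 the estimated value is 15000 nM, with an expected range from 6000 nM to 40000 nM.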

Compound 4, half-maximal effective concentration: 28000 nM
For compound 4 the middle estimate is 1.9-fold (0.27 log units) below the measured one; the range from low to high includes it.
By their numbers in this assay, from the lowest: compounds 3, 2, 4 and 1 (each within the scatter of the next, the first and the last beyond it).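

With one hydrogen of the phenyl ring replaced, so that phenyl becomes 3-methylphenyl, the series now has its first direct reading of this change in this assay: a 1.5-fold higher number from compound 2 to compound 4 (0.17 log units; within the scatter). At this place, on an aromatic carbon of a six-membered aromatic ring of carbon only and meta to a large group, the methyl therefore leaves no effect that can be told apart from the usual scatter of repeated measurements, and neither a gain nor a loss can be assigned to it. Nothing in the material shown explains the size of this step.

One hydrogen-to-methyl pair at a single place cannot show whether the same small step would hold on other carbons of this ring, on the other aromatic ring, or on the core of compound 3, which carries a carbonyl. Going by these compounds, it also remains open whether a different group at this place, such as an ethyl chain, a methoxy group, an amine or a carboxylic acid, would produce a step that stands clear of the scatter.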